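This account rests on a few compounds, and the source may have more. Where it says the series, first, only, none or still open, it means among the compounds named here.

In a physicochemical assay for lipophilicity, using the shake flask method (a lower number here means a more polar compound, a higher number a more lipophilic compound), compound 1 (`CC(C)C(=O)N1CCC(NC(=O)Nc2ccc(OC(F)(F)F)cc2)CC1`) gives 3.56. Within the data shown here, this is the lower of the two numbers available so far, since compound 2 (`O=C(Nc1ccc(C(F)(C(F)(F)F)C(F)(F)F)cc1)NC1CCN(C(=O)CC(F)(F)F)CC1`) gives 4.89, a gap beyond the usual scatter of repeat measurements. Compound 2 differs from compound 1 in more than one place, so this gap cannot be pinned on any single group.

The unmeasured compound 3 (`CCCCS(=O)(=O)N1CCC(NC(=O)Nc2ccc(OC(F)(F)F)cc2)CC1`) keeps the core of compound 1 and changes in one place only: butylsulfonyl in place of isopropylcarbonyl on an amine nitrogen in a ring. In words, butylsulfonyl stands in place of isopropylcarbonyl on an amine nitrogen in a ring. Among the measured compounds shown here, no measured pair shows this exchange, so the expectation is a judgement from the structural change alone and carries a wide margin. For compound 3, a modest rise in this assay is expected, one that may only just clear the scatter. The estimated change is a number 0.44 log units higher from compound 1 to compound 3 (beyond the scatter). For compound 3 the expected value is 4, with an estimated range from 3.5 to 4.5.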

Compound 3, partition coefficient: 4.13
The estimate for compound 3 lay 0.13 log units below the measured number; low and high end bracket the measured number.
By their numbers in this assay, from the lowest: compound 1; then compound 3; then compound 2.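

With compound 1 and compound 3, the set gains its first pair that differs in one place only, so a gap in this assay can now be tied to a single exchange: butylsulfonyl in place of isopropylcarbonyl on an amine nitrogen in a ring gives a number 0.57 log units higher from compound 1 to compound 3 (beyond the scatter) with the rest of the molecule unchanged. The number at this position therefore moves with the group on that nitrogen, yet the exchange alters several things together, since the entering group has more heavy atoms, brings in sulfur and counts more hydrogen-bond acceptors, and one step cannot tell these apart. Nothing at hand offers an explanation for the rise.

What a butylcarbonyl group or a methylsulfonyl group would give on this nitrogen stays open, so the compounds shown do not separate the sulfonyl link from the length of the chain. Equally open, going by these compounds, is how a chain ending in a carboxylic acid or an amine would read in this assay at the same place.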